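Dropping a Trifluoromethyl from the Benzyl Group of Compound 3

The compounds below may be only part of what the source reports. "The series", "measured", "known", "first", "only" and "open" are said of these compounds alone.

Of the compounds shown here, three built on a shared core have been tested in a functional assay on ASPC1 cells (Homo sapiens) for inhibition, read by MTT assay, with a stated time of 72 h; a lower number here means a stronger inhibitor of growth, a higher number a weaker inhibitor of growth. Compound 1 `CC(C)(C)c1ccc(CNCCNS(=O)(=O)c2cc(C(F)(F)F)cc(C(F)(F)F)c2)cc1` gives 14000 nM, compound 2 `COc1ccc(CNCCCNS(=O)(=O)c2cc(C(F)(F)F)cc(C(F)(F)F)c2)cc1OC` gives 6400 nM, and compound 3 `O=S(=O)(NCCCNCc1ccc(C(F)(F)F)cc1)c1cc(C(F)(F)F)cc(C(F)(F)F)c1` gives 2000 nM. Compound 3 thus shows the lowest number of the three: compound 2 comes nearest and compound 1 furthest, and both gaps lie beyond the scatter. Among the compounds with values here, the single measured step that changes one place is a 3.2-fold lower number from compound 2 to compound 3 (0.51 log units; beyond the scatter), where 4-(trifluoromethyl)phenyl replaced 3,4-dimethoxyphenyl on a saturated chain carbon bound to an amine nitrogen.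

Compound 4 `O=S(=O)(NCCCNCc1ccccc1)c1cc(C(F)(F)F)cc(C(F)(F)F)c1` differs from compound 3 by hydrogen in place of trifluoromethyl on an aromatic carbon, so 4-(trifluoromethyl)benzyl becomes benzyl. Within the data shown here, no measured step removes a trifluoromethyl outright, and the nearest guide is a 3.2-fold lower number from compound 2 to compound 3 (0.51 log units; beyond the scatter), which shows that swapping what sits on this benzyl ring shifted this assay by a modest amount. Removing the trifluoromethyl is therefore expected to move the number upward by a modest step, giving a 2.3-fold higher number from compound 3 to compound 4 (0.35 log units; beyond the scatter). Compound 4 is estimated at 4500 nM, with a range from 2000 nM to 12000 nM.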

Compound 4, concentration for 50% growth inhibition: 13000 nM
Estimate against measurement, compound 4: 2.9-fold (0.46 log units) below; measured number above the stated range.
By their numbers in this assay, from the lowest: compound 3; then compound 2; then compounds 4 and 1 (each within the scatter of the next).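

Removing the trifluoromethyl in this assay gives a 6.5-fold higher number from compound 3 to compound 4 (0.81 log units; beyond the scatter), so the group on this aromatic carbon clearly counts towards the lower number of compound 3, and the plain benzyl gives that gain up. The bare ring also provides a reference that the earlier swap between two substituted rings could not: phenyl in place of 3,4-dimethoxyphenyl gives a 2.0-fold higher number from compound 2 to compound 4 (0.31 log units; beyond the scatter), a step just beyond the scatter, so the two methoxy groups together also go with a lower number than no substituent at all, and of the three rings on this propyl-linked series the 4-(trifluoromethyl)phenyl of compound 3 has the lowest number. These numbers describe only what happens to growth inhibition, and nothing measured here explains why the trifluoromethyl has this effect.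

As far as these compounds go, whether a chlorine, a methyl or a nitrile on the same aromatic carbon would keep the lower number of compound 3 remains open. So does whether a trifluoromethyl elsewhere on the benzyl ring, or a second one, would lower the number further.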